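A few compounds are considered here, and "the series" means these few. Any claim that something is new, unique, unknown or untested is made for them only; others in the source may bear on it.

Measured so far in a functional assay on NCI-H460 cells (Homo sapiens) for inhibition, read by sulforhodamine B assay, with a stated time of 48 h; on this read-out lower numbers stand for stronger inhibition of growth and higher numbers for weaker inhibition of growth:
compound 1 `COC(=O)c1sc2cc(Nc3cc(OC)cc(OC)c3)cnc2c1N` gives 150000 nM;
compound 2 `COC(=O)c1sc2cc(Nc3cc(OC)ccc3Cl)cnc2c1N` gives 21700 nM;
compound 3 `COC(=O)c1sc2cc(Nc3ccccc3Br)cnc2c1N` gives 30900 nM.

In this assay compound 3 stands second highest of the three numbers. Its nearest neighbour is compound 2, whose value is within the scatter of that of compound 3; the furthest is compound 1, whose value lies beyond the scatter, on the weaker side.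

Compound 4 `COC(=O)c1sc2cc(Nc3ccc(F)cc3Br)cnc2c1N` is not yet measured. It differs from compound 3 by fluoro in place of hydrogen on an aromatic carbon, sitting on an aromatic carbon of a six-membered aromatic ring of carbon only, meta to a bromo group and para to a large group. Among the measured compounds shown here, no comparable pair among the measured compounds shows what such a fluoro entry does here. Without that guide the step is expected to be small, in either direction, and most likely not beyond the scatter: the estimated step is a 1.2-fold lower number from compound 3 to compound 4 (0.09 log units; within the scatter). Compound 4 is accordingly expected to give about 25000 nM, with a range from 8000 nM to 80000 nM.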

Compound 4, concentration for 50% growth inhibition: 31300 nM
For compound 4 the middle estimate is 1.3-fold (0.10 log units) below the measured one, within the range that was stated.
By their numbers in this assay, from the lowest: compounds 2, 3 and 4 (each within the scatter of the next); then compound 1.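

In this assay, fluoro in place of hydrogen on the aromatic carbon para to a large group and meta to a bromo group leaves the number unmoved (a 1.0-fold higher number from compound 3 to compound 4 (0.01 log units; within the scatter)). Among the compounds shown here, this is the only one-place comparison so far, and it shows that fluoro can enter at this position without a change beyond the scatter. No measured evidence bears on why this is so. Going by these compounds, whether an amine or a carboxylic acid at this position would also leave the number in place stays open, as does whether fluoro behaves the same way on the rings of compound 1 or compound 2.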